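The compounds below may be only part of what the source reports. "The series", "measured", "known", "first", "only" and "open" are said of these compounds alone.

Measured in an ADME assay on MDCK cells (Canis lupus familiaris) for cytotoxicity, read by MTT assay, with a stated time of 24 h; on this read-out lower numbers stand for higher toxicity in this test and higher numbers for lower toxicity in this test:
Compound 1 `N#CCCN(Cc1cccs1)S(=O)(=O)c1ccc(Br)cc1`: > 173000 nM, a limit.
Compound 2 `Cc1ccc(S(=O)(=O)N(CCC#N)Cc2cccs2)cc1`: 127000 nM.
Compound 3 `CC(=O)c1ccc(S(=O)(=O)N(CCC#N)Cc2cccs2)cc1`: > 191000 nM, a limit.

Compound 1 has only a limit and no number: the limit of > 173000 nM in this assay, at which 1 of the 3 values shown sits. Compound 3 is likewise known only as the limit of > 191000 nM in this assay, at which 1 of the 3 values shown sits.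

The next member is compound 4 `CCOC(=O)CCN(Cc1cccs1)S(=O)(=O)c1ccc(Br)cc1`, and the change is ethoxycarbonyl in place of cyano on a saturated chain carbon, two bonds along the chain from a sulfonamide nitrogen.

Within the data shown here, no measured step touches this chain. Among the measured compounds shown here, the only steps available change a group on an aromatic carbon: an at least 1.3-fold lower number from compound 1 to compound 2 (0.13 log units; that floor lies within the scatter) and an at least 1.5-fold higher number from compound 2 to compound 3 (0.17 log units; that floor lies within the scatter). Neither floor leaves the scatter, so no firm direction can be expected in this assay.

The expected result is an at least 1.0-fold lower number from compound 1 to compound 4 (0.00 log units; that floor lies within the scatter), which is no step beyond the scatter. Compound 4 is estimated at 170000 nM, within a range of 80000 nM to 350000 nM.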

Compound 4, half-maximal cytotoxic concentration: > 154000 nM
Compound 4: no number, only a limit (the forecaster's own chance of this, stated with the estimate: 50%); the middle value does not contradict the limit.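

In this assay compound 4 gives > 154000 nM, a limit. Compound 1 is also known only as a limit, so the step between compound 1 and compound 4 cannot be read. Going by these compounds, whether 2-(ethoxycarbonyl)ethyl and 2-cyanoethyl differ at all on this read-out remains open.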